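Compound 3 and its expected cytotoxicity reading

The source may report more compounds than this note shows. Statements on the series, on what has been measured and on what is new or still open speak of the compounds shown alone.

In an ADME assay on HEK293 cells (Homo sapiens) for cytotoxicity, read by CellTiter-Glo and resazurin assay, with a stated time of 72 h (a lower number here means that less compound is needed, a higher number that more compound is needed for the effect), compound 2 `CCOC(=O)CCCCCOc1cccc(CN(C(=O)c2ccc(-c3cccc(OCC)c3)cc2)C(C)C)c1` reaches only a limit, > 22300 nM, so its standing is known only as that limit. Compound 1 `CCOC(=O)CCCCCOc1cccc(CN(C(=O)c2ccc(-c3cccc(N(C)C)c3)cc2)C(C)C)c1` likewise gives only a limit in this assay, namely > 26000 nM. For the measured compounds named here, the single measured step, a step that the two limits leave unreadable from compound 1 to compound 2, therefore cannot be sized. Compound 3 `CCOC(=O)CCCCCOc1cccc(CN(C(=O)c2ccc(-c3cc(OC)cc(OC)c3)cc2)C(C)C)c1` differs from compound 2 by 3,5-dimethoxyphenyl in place of 3-ethoxyphenyl on an aromatic carbon. Going by the values given here, with no step between two readable numbers, nothing indicates a move beyond the scatter in this assay. Compound 3 is expected to give 30000 nM, within 12000 nM to 100000 nM, most likely again as a limit. The step this implies is estimated as a step that the limit leaves unreadable from compound 2 to compound 3.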

Compound 3, half-maximal effective concentration: > 26000 nM
Compound 3: only a limit was reported; the forecaster's own chance of this, stated with the estimate: 85%; the middle value does not contradict the limit.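

For the compounds shown here, compound 1, compound 2 and compound 3 all give only limits in this assay, so no step among them can be read. As far as these compounds go, the concentration at which any of them reaches the half-maximal effect stays open.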